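This account rests on a few compounds, and the source may have more. Where it says the series, first, only, none or still open, it means among the compounds named here.

The measured compounds:

Compound 1, `CCOc1cc(NC(=O)C2(NC(=O)c3ccc4c(C5CCCC5)c(-c5ncc(Cl)cn5)n(C)c4c3)CCC2)ccc1/C=C/C(=O)OCCOCCOC` — in an ADME assay for solubility (on this read-out lower numbers stand for lower solubility and higher numbers for higher solubility), compound 1 gives < 60000 ug/mL, a limit of the assay rather than a number.
Compound 2, `CCCN(C)C(=O)COC(=O)/C=C/c1ccc(NC(=O)C2(NC(=O)c3ccc4c(C5CCCC5)c(-c5ncc(Cl)cn5)n(C)c4c3)CCC2)cc1OCC` — in this assay compound 2 gives < 200000 ug/mL, again a limit.
Compound 3, `CCOc1cc(NC(=O)C2(NC(=O)c3ccc4c(C5CCCC5)c(-c5ncc(Cl)cn5)n(C)c4c3)CCC2)ccc1/C=C/C(=O)OCC(=O)N1CCCC1` — in this assay compound 3 gives < 200000 ug/mL, also a limit.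

Compound 3 therefore stands only at a limit, and the two other values shown are limits as well; two of the three sit at the limit of < 200000 ug/mL in this assay, at which 2 of the 3 values shown sit, and one at the limit of < 60000 ug/mL in this assay, at which 1 of the 3 values shown sits. From the compounds shown here alone, none of the three steps among them can be read: a step that the two limits leave unreadable from compound 1 to compound 2, a step that the two limits leave unreadable from compound 1 to compound 3 and a step that the two limits leave unreadable from compound 2 to compound 3 all stay hidden behind the limits, so their sizes and directions are unknown.

Compound 4, `CCOc1cc(NC(=O)C2(NC(=O)c3ccc4c(C5CCCC5)c(-c5ncc(Cl)cn5)n(C)c4c3)CCC2)ccc1/C=C/C(=O)OCC(=O)N1CCOCC1`, differs from compound 3 by morpholin-4-yl in place of pyrrolidin-1-yl on a carbonyl carbon whose other neighbours are a saturated chain carbon. Going by the values given here, the closest comparison is the step from compound 2 to compound 3, which also exchanges the amine on that carbonyl carbon, but it is unreadable, so no size of step in this assay can be set from it. No step beyond the scatter is expected.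

Compound 4 is expected to report 100000 ug/mL, within 30000 ug/mL to 200000 ug/mL, with the step that the limit leaves unreadable from compound 3 to compound 4 expected to be unreadable as well, most likely another limit.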

Compound 4, solubility: < 15000 ug/mL
Compound 4: a limit, no number (the forecaster's own chance of this, stated with the estimate: 80%); middle value at least 6.6-fold (0.82 log units) away from the limit.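

In this assay compound 4 gives < 15000 ug/mL, a limit of the assay and not a number. Going by these compounds alone, compound 1, compound 2 and compound 3 also stand only at limits, so no step to compound 4 can be read. The compounds shown leave open where the actual values of all four lie, and whether morpholin-4-yl in place of pyrrolidin-1-yl shifts the read-out at all.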